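The compounds below may be only part of what the source reports. "The series", "measured", "known", "first", "only" and "open" are said of these compounds alone.

Measured compounds:
compound 1, `Cc1c(C(=O)O)ccn1-c1ccccc1`, 3800 nM
compound 2, `Cc1cc(C(=O)O)c(C)n1-c1cccc(F)c1`, 1500 nM

The two measured compounds were both tested in an assay on cells for inhibition of Palmitoleoyl-protein carboxylesterase NOTUM variant C330S (Homo sapiens), read by fluorescence, with a stated time of 40 min; a lower number here means a stronger inhibitor, a higher number a weaker inhibitor. Compound 1 gives 3800 nM, and compound 2 gives 1500 nM. Of the two numbers, compound 2 holds the lower one; compound 1 stands higher by a gap that lies beyond the usual scatter of the measurement, so compound 2 is the stronger inhibitor of this pair.

The unmeasured compound 3, `Cc1cc(C(=O)O)c(C)n1-c1cccc(C2CC2)c1`, is reached from compound 2 by a single change: cyclopropyl in place of fluoro on an aromatic carbon. The fluoro group on the six-membered aromatic ring of carbon only is replaced by a cyclopropyl group at the same aromatic carbon, meta to a large group, while the shared core and its carboxylic acid are kept as they stand in compound 2.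

For the measured compounds named here, no pair of measured compounds shows what this particular exchange does, so the direction has to be taken as an expectation rather than a reading. Compound 3 is expected to give a somewhat lower number than compound 2, with the step of a 2.1-fold lower number from compound 2 to compound 3 (0.33 log units; beyond the scatter) estimated to be modest and only just beyond the scatter. On that basis compound 3 is estimated at 700 nM in this assay, with a plausible range from 200 nM to 2500 nM.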

Compound 3, half-maximal inhibitory concentration: 580 nM
For compound 3 the middle estimate is 1.2-fold (0.08 log units) above the measured one, within the range that was stated.
By their numbers in this assay, from the lowest: compound 3; then compound 2; then compound 1.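

The exchange of fluoro for cyclopropyl on the aromatic carbon meta to a large group gives a 2.6-fold lower number from compound 2 to compound 3 (0.41 log units; beyond the scatter) in this assay and is a modest step beyond the scatter. For the compounds shown here, it is the first direct reading at this place on the six-membered aromatic ring of carbon only, since no earlier pair of compounds differed there alone. It shows that this aromatic carbon accepts cyclopropyl, with its three heavy atoms and three-membered ring, in place of the single fluorine without any loss of inhibition, while the shared core and its carboxylic acid stay as they were. No measurement at hand bears on why the number falls.

The compounds shown leave open whether a cyclobutyl ring, an isopropyl group, a methoxy group or an amine on the same aromatic carbon would lower the number further or raise it again. They also leave open whether the gain from cyclopropyl would hold if the carboxylic acid were exchanged for a tetrazole, or if either methyl group on the shared core were changed.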